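Swapping the Ring-Bearing Cap of Compound 2

A few compounds are considered here, and "the series" means these few. Any claim that something is new, unique, unknown or untested is made for them only; others in the source may bear on it.

Measured so far:
compound 1 `CCOC(=O)/C=C/C(=O)N(CC(N)=O)NC(=O)[C@@H]1CCCN1C(C)=O`: 8.3 nM
compound 2 `CCOC(=O)/C=C/C(=O)N(CC(N)=O)NC(=O)[C@@H]1CCCN1C(=O)[C@H]1CCCCN1C(C)=O`: 638 nM
compound 3 `CCOC(=O)C1OC1C(=O)N(CC(N)=O)NC(=O)[C@@H]1CCCN1C(=O)C1(NC(C)=O)CC1`: 4.4 nM

In an assay on isolated protein for inhibition of legumain (Mus musculus), read by fluorescence, with stated times of 30 s and 2.5 h (on this read-out lower numbers stand for stronger inhibition and higher numbers for weaker inhibition), compound 2 stands highest of the three measured compounds. Going by the values given here, the one step that bears on the change at hand is a 77-fold higher number from compound 1 to compound 2 (1.89 log units; beyond the scatter), where a single carbon atom gave way to the ring-bearing group. Compound 4 `C#CC[C@H](NC(C)=O)C(=O)N1CCC[C@H]1C(=O)NN(CC(N)=O)C(=O)/C=C/C(=O)OCC` takes that group out again: a group of 8 heavy atoms (6 carbon, 1 nitrogen, 1 oxygen; no ring) in place of a group of 9 heavy atoms (7 carbon, 1 nitrogen, 1 oxygen; one six-membered non-aromatic ring with 1 hetero atom), on a carbonyl carbon. Among the compounds with values here, no measured step covers the entering group itself, and compound 3 carries yet another group at that carbonyl, so the size of the return is uncertain. The expectation is a step of about a 26-fold lower number from compound 2 to compound 4 (1.41 log units; beyond the scatter) back toward the lower numbers of compound 1 and compound 3. Compound 4 is therefore estimated at 25 nM, within 5 nM to 150 nM.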

Compound 4, half-maximal inhibitory concentration: 17 nM
The estimate for compound 4 lay 1.5-fold (0.17 log units) above the measured number; the measured number falls inside the stated range.
By their numbers in this assay, from the lowest: compounds 3 and 1 (each within the scatter of the next); then compound 4; then compound 2.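

In this assay, the carbonyl carbon on the amide-type nitrogen in a ring proves able to carry a large group: the ringless group with its triple bond gives a 38-fold lower number from compound 2 to compound 4 (1.57 log units; beyond the scatter). Measured against the single carbon atom, the same group gives only a 2.0-fold higher number from compound 1 to compound 4 (0.31 log units; beyond the scatter), so a high number does not follow from group size alone. The entering group differs from the leaving one in ring, triple bond and hydrogen-bond donor together, and the step cannot be assigned to any one of these.

Nothing available explains the difference. Going by these compounds, whether a saturated propyl chain, or a chain ending in an amine or carboxylic acid, would hold this level stays open.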